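Removing One Methyl on Two Related Cores

The source may hold more compounds than are shown below. What is called first, only, known or untested is meant among the compounds shown, and "the series" means these compounds.

Compound 1, `COc1ccc(C(=O)O[C@H]2C=C(C)C(=O)C[C@@]3(C)CC[C@@](O)(C(C)C)[C@H]23)cc1`, in a functional assay on K562 cells (Homo sapiens) for cytotoxicity, read by MTT assay, with a stated time of 72 h (a higher number here means a weaker inhibitor, a lower number a stronger inhibitor), gives > 100000 nM, which is a limit of the assay and not a number.
Compound 2, `CC1=C[C@H](OC(=O)c2ccc(O)cc2)[C@@H]2[C@](C)(CC[C@@]2(O)C(C)C)CC1=O`, in this assay gives > 100000 nM, again a limit of the assay and not a number.
For the measured compounds named here, compound 3, `COc1ccc(C(=O)O[C@H]2CC(C)=CC[C@@]3(C)CC[C@@](O)(C(C)C)[C@H]23)cc1`, in this assay gives 67800 nM, the only number among the three.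

All three compounds are esters of a substituted aromatic ring attached to an oxygen-bearing core. Compound 1 and compound 2 share one core and differ by a single change, (hydrogen in place of methyl on an oxygen on an aromatic ring). Compound 3 carries a different core; the difference between the two cores is not broken down here. The step that the two limits leave unreadable from compound 1 to compound 2 cannot be read, because of the limit of > 100000 nM in this assay, at which 2 of the 3 values shown sit.

Compound 4, `CC1=CC[C@@]2(C)CC[C@@](O)(C(C)C)[C@@H]2[C@@H](OC(=O)c2ccc(O)cc2)C1`, is not yet measured. It relates to compound 3 in the same way that compound 2 relates to compound 1: hydrogen in place of methyl on an oxygen on an aromatic ring. Since the place of the change is the same in both pairs, this is the same change made on a different core.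

Because compound 3 gives 67800 nM, and because the same change produced a step that the limit of > 100000 nM in this assay, at which 2 of the 3 values shown sit, leaves unreadable, compound 4 is expected to show a step of about a 1.3-fold higher number from compound 3 to compound 4 (0.10 log units; within the scatter). Compound 4 is therefore estimated at 85000 nM, most likely between 30000 nM and 250000 nM, with a real chance that only a limit is reported.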

Compound 4, half-maximal inhibitory concentration: > 100000 nM
Compound 4: only a limit was reported; the forecaster's own chance of this, stated with the estimate: 45%; middle value at least 1.1-fold (0.07 log units) from the limit.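

Going from methoxy to hydroxy on the core of compound 3 gives, in this assay, an at least 1.4-fold higher number from compound 3 to compound 4 (0.16 log units; that floor lies within the scatter), and this is a floor on the step, not its size. On these data alone, compound 4 gives > 100000 nM, which is a limit of the assay and not a number, so the change gives no sign of a stronger compound on this core, but how large the loss is, and whether it exceeds the scatter, stays unknown. The same change on the core of compound 1 cannot be read, so the two steps cannot be set side by side, and nothing shows whether the change behaves alike on both cores, because most of the values stop at the same limit: the limit of > 100000 nM in this assay, at which 3 of the 4 values shown sit.

As far as these compounds go, only methoxy and hydroxy appear on the aromatic ring here, so it remains open whether another group in that place, such as an amine or a carboxylic acid, would give a readable number on either core. For the compounds shown here, also open is which feature of the core matters, as the two cores are not connected by a single change and compound 3, at 67800 nM, is the only compound with a number.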